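Triazole substituent swap in a weakly active furanone series

This account rests on a few compounds, and the source may have more. Where it says the series, first, only, none or still open, it means among the compounds named here.

The compounds share one core and differ only in the group on an aromatic carbon of the five-membered aromatic ring with 3 nitrogen. Compound 1 `C[Si](C)(C)c1cn(C[C@H](O)[C@H]2OC(=O)C(OCc3ccccc3)=C2OCc2ccccc2)nn1` gives 31800 nM in a functional assay on HCT-116 cells (Homo sapiens) for antiproliferative activity, read by MTT assay, with a stated time of 72 h; a lower number here means a stronger inhibitor, a higher number a weaker inhibitor. Compound 3 `O=C1O[C@H]([C@@H](O)Cn2cc(-c3cc(C(F)(F)F)cc(C(F)(F)F)c3)nn2)C(OCc2ccccc2)=C1OCc1ccccc1` gives 57200 nM in this assay. Compound 2 `COc1ccc(-c2cn(C[C@H](O)[C@H]3OC(=O)C(OCc4ccccc4)=C3OCc3ccccc3)nn2)cc1` reaches only a limit of the assay, > 100000 nM in this assay, so compound 2 stands at the limit of > 100000 nM in this assay, at which 1 of the 3 values shown sits, and is the weakest of the three measured compounds on the numbers shown. Going by the values given here, the only measured step that touches compound 2 is an at least 3.1-fold higher number from compound 1 to compound 2 (0.49 log units; beyond the scatter). Compound 4 `O=C1O[C@H]([C@@H](O)Cn2cc(CNS(=O)(=O)c3ccc(Cl)cc3)nn2)C(OCc2ccccc2)=C1OCc1ccccc1` differs from compound 2 by (((4-chlorophenyl)sulfonyl)amino)methyl in place of 4-methoxyphenyl on an aromatic carbon. Among the compounds with values here, that single step is the only one bearing on the change: it shows that the group at this position can shift the number by a modest amount, but it gives no direction for the entering group. Because compound 2 sits at a limit, the expected step of an at least 2.2-fold lower number from compound 2 to compound 4 (0.34 log units; beyond the scatter) is taken as a return toward the numbers of compound 1 and compound 3, with a further limit still possible. Compound 4 is therefore estimated at 45000 nM in this assay, with a range from 12000 nM to 150000 nM.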

Compound 4, half-maximal inhibitory concentration: 8380 nM
For compound 4 the middle estimate is 5.4-fold (0.73 log units) above the measured one; measured number outside the range, below it.
By their numbers in this assay, from the lowest: compound 4; then compounds 1 and 3 (each within the scatter of the next). At a limit, above all of these: compound 2.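

In this assay, going by these compounds alone, the only earlier step at this aromatic carbon ran toward a higher number, while the new result gives a step the other way: a 3.8-fold lower number from compound 1 to compound 4 (0.58 log units; beyond the scatter). Setting (((4-chlorophenyl)sulfonyl)amino)methyl in place of 4-methoxyphenyl gives a large change, an at least 11-fold lower number from compound 2 to compound 4 (1.07 log units; beyond the scatter), so the group here can move the number in either direction. This step is only a bound, as compound 2 gives a limit of the assay and not a number: the limit of > 100000 nM in this assay, at which 1 of the 4 values shown sits.

The compounds shown do not separate the contributions of the sulfonyl, the amino hydrogen and the 4-chlorophenyl ring, as these enter together. From the compounds shown here alone, how a plain aminomethyl group, a carboxylic acid or a longer chain between the sulfonyl and the ring would read at this aromatic carbon also remains open.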